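A Benzyl Group on the Ring Nitrogen of Compound 2

The compounds below may be only part of what the source reports. "The series", "measured", "known", "first", "only" and "open" are said of these compounds alone.

Measured so far:
- compound 1, `Cc1ccc(NC(=S)N/N=C2\C(=O)Nc3ccc(Br)cc32)cc1`: 6800 nM
- compound 2, `Cc1ccc(NC(=S)N/N=C2\C(=O)Nc3ccc(F)cc32)cc1`: 4800 nM
- compound 3, `O=C1Nc2ccc(F)cc2/C1=N/NC(=S)Nc1ccc(Cl)cc1`: 25000 nM

In a functional assay on CCRF-CEM cells (Homo sapiens), with a stated time of 72 h (on this read-out lower numbers stand for stronger inhibition and higher numbers for weaker inhibition), compound 2 gives the lowest of the three numbers. Its nearest neighbour is compound 1, and the step of a 1.4-fold lower number from compound 1 to compound 2 (0.15 log units; within the scatter) stays within the scatter, so the two cannot be told apart. Among the measured compounds shown here, compound 3 is the furthest away: the step of a 5.2-fold higher number from compound 2 to compound 3 (0.72 log units; beyond the scatter) goes beyond the scatter, and it is the only clear change among the three.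

Compound 4, `Cc1ccc(NC(=S)N/N=C2\C(=O)N(Cc3ccc(F)cc3)c3ccc(F)cc32)cc1`, differs from compound 2 by 4-fluorobenzyl in place of hydrogen on an amide-type nitrogen in a ring. Neither measured step bears on this change: both concern swaps on aromatic carbons, the first a halogen for a halogen, the second a halogen for a methyl, whereas here a whole 4-fluorobenzyl group enters on the ring nitrogen. For the measured compounds named here, the data give no step of this kind, so the direction in this assay cannot be read off. The expectation for compound 4 is therefore anchored at compound 2 with a wide range, a step of a 1.2-fold lower number from compound 2 to compound 4 (0.08 log units; within the scatter). Compound 4 is estimated at 4000 nM, between 1000 nM and 16000 nM.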

Compound 4, half-maximal inhibitory concentration: 2500 nM
Compound 4: middle estimate off by 1.6-fold (0.20 log units), on the high side, within the range that was stated.
By their numbers in this assay, from the lowest: compounds 4, 2 and 1 (each within the scatter of the next, the first and the last beyond it); then compound 3.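

In this assay, the step of a 1.9-fold lower number from compound 2 to compound 4 (0.28 log units; within the scatter) stays within the scatter, so compound 2 and compound 4 cannot be told apart. Among the compounds shown here, the earlier steps all lay on aromatic carbons, and this is the first reading at the amide-type nitrogen in a ring: here the hydrogen gives way to 4-fluorobenzyl, with its 8 heavy atoms, and no clear change in the number follows. Nothing in the information at hand accounts for this result.

From the compounds shown here alone, whether an unsubstituted benzyl group, a small methyl group, or a longer chain ending in an amine or a carboxylic acid would read the same on this nitrogen stays open. Also open, going by these compounds, is whether the step of a 5.2-fold higher number from compound 2 to compound 3 (0.72 log units; beyond the scatter) would repeat with 4-fluorobenzyl on the ring nitrogen.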